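Swapping a fluorophenyl for a pyridyl on the benzylic arm

The source may report more compounds than this note shows. Statements on the series, on what has been measured and on what is new or still open speak of the compounds shown alone.

Measured compounds:
compound 1, `CCN(Cc1cccc(Br)c1)c1ccc(C(=O)N2CCc3ccc(OS(N)(=O)=O)cc3C2)cc1`, 1.93
compound 2, `CCN(Cc1ccc(F)cc1)c1ccc(C(=O)N2CCc3ccc(OS(N)(=O)=O)cc3C2)cc1`, 1.93
compound 3, `NS(=O)(=O)Oc1ccc2c(c1)CN(C(=O)c1ccc(N3CCC(Cc4ccccc4)CC3)cc1)CC2`, 3.87

For the measured compounds named here, in a physicochemical assay for lipophilicity (on this read-out higher numbers stand for higher lipophilicity and lower numbers for lower lipophilicity), compound 2 gives 1.93 and stands level with compound 1, the two together being the lowest of the three numbers; compound 3 lies far higher at 3.87, a gap beyond the scatter, and no single-point step connects it to compound 2.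

Compound 4, `CCN(Cc1ccncc1)c1ccc(C(=O)N2CCc3ccc(OS(N)(=O)=O)cc3C2)cc1`, has not yet been measured. It differs from compound 2 in one place: pyridin-4-yl in place of 4-fluorophenyl on a saturated chain carbon bound to a nitrogen on an aromatic ring. A six-membered aromatic ring with one hetero atom and one hydrogen-bond acceptor enters where a ring of carbon only left.

Going by the values given here, only one measured step touches this position: no change at the digits printed from compound 1 to compound 2 (within the scatter), a halogen-for-halogen exchange on an all-carbon ring that left the read-out unmoved. Among the compounds with values here, no measured step introduces a ring nitrogen, so the expectation rests on the loss of fluorine and the gain of an acceptor in the count above.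

Compound 4 is therefore expected to move down in this assay by a number 1.33 log units lower from compound 2 to compound 4 (beyond the scatter), and its value is estimated at 0.6, within a range from 0 to 1.2.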

Compound 4, partition coefficient: 1.93
The estimate for compound 4 lay 1.33 log units below the measured number, and the stated range ends below it.
By their numbers in this assay, from the lowest: compounds 1, 2 and 4 (each within the scatter of the next); then compound 3.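

In this assay, pyridin-4-yl in place of 4-fluorophenyl, on a saturated chain carbon bound to a nitrogen on an aromatic ring, gave no change at the digits printed from compound 2 to compound 4 (within the scatter), so this position has now taken a ring with a hetero atom and a hydrogen-bond acceptor with no step beyond the scatter. Set against the 3-bromophenyl group, the same ring gave no change at the digits printed from compound 1 to compound 4 (within the scatter), which places all three rings tested here within the scatter of one another. Nothing on hand accounts for this result.

As far as these compounds go, whether a carboxylic acid, a primary amine or a longer chain at this position would also stay within the scatter remains open. Compound 3, at 3.87, differs from these three in more than one place, so what sets its number apart cannot be read.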